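Chloro in Place of Nitro in a Flat Series

The source may report more compounds than this note shows. Statements on the series, on what has been measured and on what is new or still open speak of the compounds shown alone.

In a functional assay on T47D cells (Homo sapiens) for cytotoxicity, read by MTT assay, with a stated time of 48 h (on this read-out higher numbers stand for weaker inhibition and lower numbers for stronger inhibition), compound 1 `COc1ccc(NC(=S)N/N=C\c2ccnc3ccccc23)cc1` gives 1360 nM, compound 2 `CCc1ccc(NC(=S)N/N=C\c2ccnc3ccccc23)cc1` gives 1280 nM, and compound 3 `O=[N+]([O-])c1ccc(NC(=S)N/N=C\c2ccnc3ccccc23)cc1` gives 1330 nM, which leaves compound 3 level with the other two within the scatter. Compound 4 `S=C(N/N=C\c1ccnc2ccccc12)Nc1ccc(Cl)cc1` remains unmeasured. It carries chloro in place of nitro on an aromatic carbon, para to a large group: chloro in place of nitro on an aromatic carbon. Three measured steps change the group at that same place: a 1.1-fold lower number from compound 1 to compound 2 (0.03 log units; within the scatter), a 1.0-fold lower number from compound 1 to compound 3 (0.01 log units; within the scatter) and a 1.0-fold higher number from compound 2 to compound 3 (0.02 log units; within the scatter), each within the scatter. No step beyond the scatter is therefore expected in this assay. The expected change is a 1.0-fold lower number from compound 3 to compound 4 (0.01 log units; within the scatter). The estimate for compound 4 is 1300 nM, with an expected range from 800 nM to 2100 nM.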

Compound 4, half-maximal inhibitory concentration: 1270 nM
Beside the measured number, compound 4's estimate is 1.0-fold (0.01 log units) above it; low and high end bracket the measured number.
By their numbers in this assay, from the lowest: compounds 4, 2, 3 and 1 (each within the scatter of the next).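

With chloro at this place, on an aromatic carbon para to a large group, this assay gives a 1.0-fold lower number from compound 3 to compound 4 (0.02 log units; within the scatter) and a 1.0-fold lower number from compound 2 to compound 4 (0.00 log units; within the scatter) and a 1.1-fold lower number from compound 1 to compound 4 (0.03 log units; within the scatter). A single chlorine atom entering for the three heavy atoms of nitro thus leaves the number level, and chloro joins methoxy, ethyl and nitro in a flat set at this position. No measured evidence bears on why the position stays flat. The compounds shown leave open whether an amine, a carboxylic acid or a longer chain at this place would also stay level, and whether a change elsewhere on the shared core would move the number.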